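The source may report more compounds than this note shows. Statements on the series, on what has been measured and on what is new or still open speak of the compounds shown alone.

Compound 1 `CCCC/N=c1\c(O)c(O)\c1=N/Cc1ccc(C#N)cc1` opens the series. In a functional assay for inhibition, with Rattus norvegicus as the target (on this read-out higher numbers stand for weaker inhibition and lower numbers for stronger inhibition), compound 1 gives > 30000 nM, which is a limit of the assay and not a number; the line the limit of > 30000 nM in this assay, at which 1 of the 2 values shown sits, records that limit. Going by the values given here, compound 2 `CCC(C)(C)/N=c1\c(O)c(O)\c1=N/Cc1ccc(C#N)c(Cl)c1`, differing in two places, gives 260 nM in this assay, so the pair shows only that a branched group on the double-bonded nitrogen together with a chlorine reaches measurable inhibition. Compound 3 `CC(C)(CO)/N=c1\c(O)c(O)\c1=N/Cc1ccc(C#N)cc1` carries 1-(hydroxymethyl)-1-methylethyl in place of butyl on a double-bonded nitrogen relative to compound 1. Among the compounds with values here, no measured step covers this change alone. For compound 3 the expected step is an at least 5.0-fold lower number from compound 1 to compound 3 (0.69 log units; beyond the scatter), a move to stronger inhibition. The estimate for compound 3 is 6000 nM, within 600 nM to 40000 nM.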

Compound 3, half-maximal inhibitory concentration: 21300 nM
Beside the measured number, compound 3's estimate is 3.6-fold (0.55 log units) below it; measured number inside the range.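

In this assay, going by these compounds alone, 1-(hydroxymethyl)-1-methylethyl in place of butyl on a double-bonded nitrogen is the first change that can be read alone, and it gives an at least 1.4-fold lower number from compound 1 to compound 3 (0.14 log units; that floor lies within the scatter). The true size of this step stays open, and no firm gain can be claimed, because compound 1 stands at a limit of the assay: the limit of > 30000 nM in this assay, at which 1 of the 3 values shown sits.

The compounds shown leave open whether the branching or the hydroxymethyl carries the step. As far as these compounds go, how an amine or a carboxylic acid in this place would read also remains unknown.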